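Oxymethylene spacer inserted before the tetrazole of compound 1

The source may report more compounds than this note shows. Statements on the series, on what has been measured and on what is new or still open speak of the compounds shown alone.

For the measured compounds named here, compound 1 `c1cc(OCc2ccc3ccccc3n2)cc(-c2nn[nH]n2)c1` holds the lowest of the two numbers measured so far in a functional assay (Cavia porcellus) for inhibition of cysteinyl leukotriene receptor (Homo sapiens) (on this read-out higher numbers stand for weaker inhibition and lower numbers for stronger inhibition), compound 1 giving 200 nM. Going by the values given here, compound 2 `c1ccc2nc(COc3ccc(Cc4nnn[nH]4)cc3)ccc2c1` gives 1000 nM in this assay, a higher number than that of compound 1 and beyond the usual scatter; compound 2 differs from compound 1 in more than one place, so no single step between the two is counted, and only the two values themselves can be read. Compound 3 `c1cc(OCc2ccc3ccccc3n2)cc(OCc2nn[nH]n2)c1` has not yet been measured in this assay. It differs from compound 1 in one place: (2H-tetrazol-5-yl)methoxy in place of 2H-tetrazol-5-yl on an aromatic carbon. Among the compounds with values here, no measured pair shows a change of this kind on the shared core, so the size and direction of the step rest on the two values alone, and the expectation carries a wide range. A modest weakening is expected, a 2.3-fold higher number from compound 1 to compound 3 (0.35 log units; beyond the scatter), because compound 2 with a one-carbon link to its tetrazole gives 1000 nM. The estimate for compound 3 is 450 nM, with a range from 120 nM to 2000 nM.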

Compound 3, half-maximal inhibitory concentration: 140 nM
Beside the measured number, compound 3's estimate is 3.2-fold (0.51 log units) above it; the measured number falls inside the stated range.
By their numbers in this assay, from the lowest: compounds 3 and 1 (each within the scatter of the next); then compound 2.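

In this assay, (2H-tetrazol-5-yl)methoxy in place of 2H-tetrazol-5-yl on an aromatic carbon, meta to a large group, gives a 1.4-fold lower number from compound 1 to compound 3 (0.15 log units; within the scatter). For the compounds shown here, this is the first pair that differs in one place, and it shows that at this position the tetrazole can sit directly on the ring or on the methoxy link, 7 heavy atoms in place of 5, with two numbers that cannot be told apart on this read-out. Nothing available on the properties of these compounds bears on this result, so the step stands as an observation only.

The compounds shown leave open whether a carboxylic acid can stand in for the tetrazole at this position, and whether a longer chain, such as a (2H-tetrazol-5-yl)ethoxy group, still gives a number within the scatter of compound 1. Also open, going by these compounds, is what the oxygen of the link contributes, a question that a (2H-tetrazol-5-yl)methyl group at this same position on the shared core would address.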